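Swapping the Hydroxyphenyl for Chlorophenyl in a Thiosemicarbazone

This account rests on a few compounds, and the source may have more. Where it says the series, first, only, none or still open, it means among the compounds named here.

Compound 1 `CC1=CC[C@H](C(C)(C)NC(=S)N/N=C/c2ccc(O)cc2)CC1` is the starting point. In a functional assay on U-251 cells (Homo sapiens) for inhibition, read by sulforhodamine B assay, with a stated time of 48 h (on this read-out lower numbers stand for stronger inhibition of growth and higher numbers for weaker inhibition of growth), compound 1 reaches only a limit, > 100000 nM, so its true number is not known. That value is the limit of > 100000 nM in this assay, at which 1 of the 2 values shown sits. Compound 2 `CC1=CC[C@H](C(C)(C)NC(=S)N/N=C/c2ccc(N(C)C)cc2)CC1` gives 57700 nM in this assay, which makes an at least 1.7-fold lower number from compound 1 to compound 2 (0.23 log units; that floor lies within the scatter). Compound 3 `CC1=CC[C@H](C(C)(C)NC(=S)N/N=C/c2ccccc2Cl)CC1` differs from compound 1 by 2-chlorophenyl in place of 4-hydroxyphenyl on a carbon with a double bond to nitrogen. For the measured compounds named here, no measured step covers this change; the one known step concerned a different group and barely left the scatter. Compound 3 is therefore expected to remain weak, with an at least 1.2-fold lower number from compound 1 to compound 3 (0.09 log units; that floor lies within the scatter). Compound 3 is estimated at 80000 nM, between 30000 nM and 200000 nM.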

Compound 3, concentration for 50% growth inhibition: 80600 nM
The estimate for compound 3 lay 1.0-fold (0.00 log units) below the measured number; measured number inside the range.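

The change from 4-hydroxyphenyl to 2-chlorophenyl on a carbon with a double bond to nitrogen gives an at least 1.2-fold lower number from compound 1 to compound 3 (0.09 log units; that floor lies within the scatter). Compound 3 thus yields a measured number in this assay even though its 2-chlorophenyl counts no hydrogen-bond donor or acceptor. Compound 1 reaches only a limit, so the true size of this change cannot be read: the limit of > 100000 nM in this assay, at which 1 of the 3 values shown sits.

The compounds shown leave open whether the chlorine itself or its place on the ring matters, as both change in this one step. Going by these compounds, how a ring carrying a methoxy group or a carboxylic acid would read also stays open.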